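Compound 3 to compound 4: a shorter amine-bearing acyl group

This account rests on a few compounds, and the source may have more. Where it says the series, first, only, none or still open, it means among the compounds named here.

Values measured so far in a functional assay on SU-DHL-6 cells (Homo sapiens) for antiproliferative activity, read by MTT assay (a lower number here means a stronger inhibitor, a higher number a weaker inhibitor), are these:
compound 1 `COc1ncc(-c2ccc3ncnc(N[C@H]4CCCN(C(=O)C(F)(F)F)C4)c3c2)cc1C#N` gives 210 nM
compound 2 `COc1ncc(-c2ccc3ncnc(N[C@H]4CCCN(C(=O)CCBr)C4)c3c2)cc1C#N` gives 15 nM
compound 3 `COc1ncc(-c2ccc3ncnc(N[C@H]4CCCN(C(=O)C5CCN(C)CC5)C4)c3c2)cc1C#N` gives 420 nM
compound 4 `COc1ncc(-c2ccc3ncnc(N[C@H]4CCCN(C(=O)CN(C)C)C4)c3c2)cc1C#N` has no value yet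

Compound 3 reads 420 nM and is the starting point here. Against the trifluoromethyl amide the step is a 2.0-fold higher number from compound 1 to compound 3 (0.30 log units; within the scatter) and no order can be given for that pair. Against the 2-bromoethyl amide the step is a 28-fold higher number from compound 2 to compound 3 (1.45 log units; beyond the scatter) and that separation is large.

The step to compound 4 is (dimethylamino)methyl in place of 1-methylpiperidin-4-yl on a carbonyl carbon and so puts (dimethylamino)methyl in place of 1-methylpiperidin-4-yl on a carbonyl carbon. Within the data shown here, no measured compound carries (dimethylamino)methyl, so the evidence is indirect. Going from trifluoromethyl to 2-bromoethyl gave a 14-fold lower number from compound 1 to compound 2 (1.15 log units; beyond the scatter) and only compound 2 stands apart among the three. Compound 1 and compound 3 carry very different groups, yet their values do not separate. These three compounds give no ground for carrying the large shift of compound 2 over to the new group. No step beyond the scatter is expected, and the estimated step is a 1.4-fold lower number from compound 3 to compound 4 (0.15 log units; within the scatter) in this assay on present evidence. Compound 4 is estimated at 300 nM with an expected range of 90 nM to 900 nM as the working figure.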

Compound 4, half-maximal inhibitory concentration: 160 nM
Beside the measured number, compound 4's estimate is 1.9-fold (0.27 log units) above it, and the stated range covers the measured number.
By their numbers in this assay, from the lowest: compound 2; then compounds 4, 1 and 3 (each within the scatter of the next, the first and the last beyond it).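

In this assay, putting the open-chain (dimethylamino)methyl in place of the ring-bearing 1-methylpiperidin-4-yl on the carbonyl carbon gives a 2.6-fold lower number from compound 3 to compound 4 (0.42 log units; beyond the scatter) and so shows that two amine-bearing acyl groups can separate at this position, though only modestly. The 2-bromoethyl amide stays well apart from the new group, with an 11-fold higher number from compound 2 to compound 4 (1.03 log units; beyond the scatter) as the step, whereas the trifluoromethyl amide does not separate from it, with a 1.3-fold lower number from compound 1 to compound 4 (0.12 log units; within the scatter) as the step, so compound 2 remains the only one of the four set apart from all the others. No measurement is available here that would account for the size of any of these steps.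

Still open, as far as these compounds go, is whether the low number of compound 2 belongs to the bromine or to the ethyl chain that carries it, a question that 2-chloroethyl or plain ethyl on the carbonyl carbon would address. Also open, from the compounds shown here alone, is how a longer chain such as 2-(dimethylamino)ethyl, or a ring amine such as morpholin-4-ylmethyl, would stand against (dimethylamino)methyl.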